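Shortening the Chain on a Shared Core

The source may hold more compounds than are shown below. What is called first, only, known or untested is meant among the compounds shown, and "the series" means these compounds.

Three compounds have been measured in a functional assay on aorta with Alpha-1D adrenergic receptor (Rattus norvegicus) as the target; a lower number here means that less compound is needed, a higher number that more compound is needed for the effect:

Compound 1, `CSc1ccc(Cc2nn(C(C)(C)C)c(=O)c3ccccc23)cc1`, gives > 100000 nM, which is a limit of the assay and not a number.
Compound 2, `Cn1nc(Cc2ccc(Cl)cc2Cl)c2ccccc2c1=O`, gives 1200 nM.
Compound 3, `CCCCn1nc(Cc2ccc(OC)c(OC)c2)c2ccccc2c1=O`, gives 5400 nM.

Compound 3 stands highest of the two real numbers in this assay; the nearest, compound 2, sits lower by a gap that lies beyond the usual scatter of repeated measurements. The value of compound 1 is a limit only (the limit of > 100000 nM in this assay, at which 1 of the 3 values shown sits), so it does not rank.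

Compound 4, `CCn1nc(Cc2ccc(OC)c(OC)c2)c2ccccc2c1=O`, has not yet been measured. It differs from compound 3 in one place: hydrogen in place of ethyl on a saturated chain carbon, two bonds along the chain from an aromatic nitrogen. Put differently, the butyl on the shared core becomes an ethyl. Among the compounds with values here, no pair of measured compounds differs by this change alone, so its size has not been seen. Compound 2 carries a methyl, but its other ring also differs from that of compound 3, so its value cannot be split between the two changes. With nothing to point to, a step no larger than the usual scatter is expected from compound 3 to compound 4, in either direction.

Compound 4 is therefore expected to give about 4500 nM, somewhere between 1500 nM and 14000 nM. The expected step of a 1.2-fold lower number from compound 3 to compound 4 (0.08 log units; within the scatter) is a small one.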

Compound 4, half-maximal effective concentration: 5300 nM
Compound 4: the middle estimate sits 1.2-fold (0.07 log units) below what was measured; the range from low to high includes it.
By their numbers in this assay, from the lowest: compound 2; then compounds 4 and 3 (each within the scatter of the next). At a limit, above all of these: compound 1.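

In this assay, the change from butyl to ethyl on the shared core now has a measured size, with the other ring held the same: the step is a 1.0-fold lower number from compound 3 to compound 4 (0.01 log units; within the scatter). Within this one pair, then, the two chains on the aromatic nitrogen cannot be told apart, so the full length of the butyl is not needed to keep the reading seen for compound 3. Nothing measured here offers a reason why the two chains read alike.

This single step says nothing yet about how other chains at this position would read, such as a longer hexyl chain, a chain ending in an amine or one ending in a carboxylic acid, and it is also unknown whether butyl and ethyl would read alike with a different ring at the other end of the core. Compound 1 gives > 100000 nM, which is a limit of the assay and not a number, and as it differs from the other compounds in more than one place, it cannot settle these questions.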